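A few compounds are considered here, and "the series" means these few. Any claim that something is new, unique, unknown or untested is made for them only; others in the source may bear on it.

Compound 2 `COC(=O)/C=C/c1cccc(N(Cc2ccc(/C=C/c3ccccn3)cc2)C(=O)C2CCCCC2)c1` gives 309 nM in an assay on isolated protein with Bile acid receptor (Homo sapiens) as the target (a higher number here means that more compound is needed for the effect, a lower number that less compound is needed), the second highest of the three numbers measured. Compound 3 `COC(=O)/C=C/c1cccc(N(Cc2ccc(/C=C/c3ccccn3)cc2)C(=O)C(C)C)c1` gives 310 nM, and a 1.0-fold higher number from compound 2 to compound 3 (0.00 log units; within the scatter). Compound 1 `COC(=O)/C=C/c1cccc(N(Cc2ccc(/C=C/c3ccc(F)cc3)cc2)C(=O)C(C)C)c1` gives 120 nM, and a 2.6-fold higher number from compound 1 to compound 3 (0.41 log units; beyond the scatter). Compound 4 `CCOc1cccc(-c2ccc(CN(C(=O)C3CCCCC3)c3cccc(/C=C/C(=O)OC)c3)cc2)c1` has not been measured; it differs from compound 2 in that (3-ethoxyphenyl in place of 2-(pyridin-2-yl)ethenyl on an aromatic carbon). Going by the values given here, only the step from compound 1 to compound 3 touches the same region, where swapping the ring at the end of the chain shifted the number, yet no measured pair removes the chain itself. The expectation is therefore a step of uncertain direction, a 1.4-fold lower number from compound 2 to compound 4 (0.15 log units; within the scatter), with wide margins. Compound 4 is expected to give about 220 nM in this assay, between 50 nM and 1000 nM.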

Compound 4, half-maximal effective concentration: 147 nM
Compound 4: the middle estimate sits 1.5-fold (0.18 log units) above what was measured; low and high end bracket the measured number.
By their numbers in this assay, from the lowest: compounds 1 and 4 (each within the scatter of the next); then compounds 2 and 3 (each within the scatter of the next).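

In this assay, the 2-(pyridin-2-yl)ethenyl group on this aromatic carbon, para to a large group, can be replaced outright, with 3-ethoxyphenyl giving a 2.1-fold lower number from compound 2 to compound 4 (0.32 log units; beyond the scatter) in place of the earlier ring swap at the end of the chain. This time the double bond outside the aromatic rings goes as well, and the number still does not rise. The compounds shown cannot separate the loss of that double bond from the arrival of the new ring, and whether an unsubstituted phenyl, or an amine in place of the ethoxy group, would give a similar number stays open. No measured evidence explains this step.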